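Trifluoromethyl in place of ethyl: notes on the series

The source may report more compounds than this note shows. Statements on the series, on what has been measured and on what is new or still open speak of the compounds shown alone.

Measured in a functional assay on HL-60 cells (Homo sapiens) for inhibition, read by MTT assay, with a stated time of 72 h (a higher number here means a weaker inhibitor, a lower number a stronger inhibitor), so far:
- compound 1 `CCc1nc(-c2ccccc2F)c(C(=O)N2CCN(c3cccc(Cl)c3)CC2)o1` gives 139 nM
- compound 2 `Cc1nc(-c2ccccc2F)c(C(=O)N2CCN(c3cc(Cl)ccc3C)CC2)o1` gives 229 nM
- compound 3 `COc1cccc(N2CCN(C(=O)c3oc(C(F)(F)F)nc3-c3cccc(F)c3)CC2)c1` is reported as "not active" (no number reported) without a number

Among the measured compounds shown here, compound 1 stands with compound 2 among the only two compounds that have numbers, and these two numbers lie within the usual scatter of each other. The third entry offers no number to place it against them.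

The next compound to be read is compound 4 `O=C(c1oc(C(F)(F)F)nc1-c1ccccc1F)N1CCN(c2cccc(Cl)c2)CC1`, which keeps the core of compound 1 and carries trifluoromethyl in place of ethyl on an aromatic carbon. For the measured compounds named here, no pair of measured compounds shows this change on its own, so there is no direct measure of its size.

Going by the values given here, the only indirect evidence is compound 3, the one measured compound with trifluoromethyl, which is recorded as "not active" (no number reported) in this assay. This single entry points towards a weaker compound 4, but it is thin support, and a number in the same range as compound 1 remains possible.

A rise beyond the scatter is therefore expected, with the estimated step of a 3.6-fold higher number from compound 1 to compound 4 (0.56 log units; beyond the scatter) in this assay. The estimate for compound 4 is 500 nM, with an expected range from 120 nM to 3000 nM and a real chance that no number is reported.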

Compound 4, half-maximal inhibitory concentration: "not active" (no number reported)
The entry for compound 4 holds no number; no gap can be computed for the estimate.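

In this assay, among the compounds shown here, compound 4 is entered as "not active" (no number reported), so no step from compound 1 to compound 4 can be read. The compounds shown leave open the size of the change from ethyl to trifluoromethyl on its own; neither compound 3 nor compound 4 carries a number. No evidence shown bears on this result.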